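Bromo to methoxy on the benzyl group: compound 4

A few compounds are considered here, and "the series" means these few. Any claim that something is new, unique, unknown or untested is made for them only; others in the source may bear on it.

Measured so far in an assay on isolated protein for displacement of a labelled ligand from D(4) dopamine receptor (Homo sapiens); on this read-out lower numbers stand for stronger inhibition and higher numbers for weaker inhibition:
compound 1 `O=C(NC1CCN(Cc2cccc(Br)c2)CC1)c1cccc2ccccc12`: 66 nM
compound 2 `O=C(NC1CCN(Cc2cccc(C(F)(F)F)c2)CC1)c1cccc2ccccc12`: 119 nM
compound 3 `O=C(NC1CCN(Cc2cccc(Br)c2)CC1)c1ccc2ccccc2c1`: 36 nM

Compound 3 gives the lowest of the three numbers in this assay. Its gap to compound 1 lies within the usual scatter, so the two cannot be ordered; its gap to compound 2 lies beyond it.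

Compound 4 `COc1cccc(CN2CCC(NC(=O)c3ccc4ccccc4c3)CC2)c1` is the next compound. It differs from compound 3 in one place: methoxy in place of bromo on an aromatic carbon.

Going by the values given here, only one measured step bears on this change, the one from compound 1 to compound 2, in which the same bromo group at the same place was replaced by trifluoromethyl: a 1.8-fold higher number from compound 1 to compound 2 (0.26 log units; within the scatter). That exchange moved the number by less than the scatter. Among the compounds with values here, no compound in the set carries a methoxy group, so the step to compound 4 rests on this single analogy. A small shift is therefore expected, estimated as a 1.7-fold higher number from compound 3 to compound 4 (0.22 log units; within the scatter), with the direction uncertain and leaning toward a somewhat higher number.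

For compound 4 in this assay the expected value is 60 nM, with a plausible range from 20 nM to 180 nM.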

Compound 4, inhibition constant: 16 nM
Beside the measured number, compound 4's estimate is 3.8-fold (0.57 log units) above it; measured number below the stated range.
By their numbers in this assay, from the lowest: compound 4; then compounds 3, 1 and 2 (each within the scatter of the next, the first and the last beyond it).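

Working notes on the benzyl substituent: in this assay, methoxy in place of bromo gives a 2.3-fold lower number from compound 3 to compound 4 (0.35 log units; beyond the scatter), so this position on the ring can respond to an exchange by more than the scatter. Going by these compounds alone, the only earlier exchange of bromo at this place, a 1.8-fold higher number from compound 1 to compound 2 (0.26 log units; within the scatter), stayed within the scatter, and it was made on the core of compound 1, so the two steps differ in both the entering group and the core. By the computed counts, methoxy carries 1 hydrogen-bond acceptor and bromo 0, but no measurement here gives a reason for the lower number in compound 4.

From the compounds shown here alone, it remains open whether methoxy in place of bromo gives a similar step on the core of compound 1, where the direct comparison would be with compound 1 itself. Also open, going by these compounds, is how the number responds at the same place on the core of compound 4 to a hydroxyl, an ethoxy group or a dimethylamino group, which would test whether the change follows the oxygen atom or the longer substituent.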